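Bromo to iodo on the thiourea aryl ring

The source may hold more compounds than are shown below. What is called first, only, known or untested is meant among the compounds shown, and "the series" means these compounds.

Measured compounds in a functional assay on HL-60 cells (Homo sapiens) for antiproliferative activity, with a stated time of 24 h; on this read-out higher numbers stand for weaker inhibition and lower numbers for stronger inhibition:
compound 1, `NC(=O)c1c(NC(=O)c2ccccc2Cl)sc2c1CCN(Cc1ccc(Cl)cc1Cl)C2`, 8010 nM
compound 2, `NC(=O)c1c(NC(=O)c2ccccc2Cl)sc2c1CCN(C(=S)Nc1ccccc1Br)C2`, 9090 nM

Compound 2 holds the highest of the two numbers shown, and its only neighbour is compound 1, which sits within the scatter of it; the one measured step, a 1.1-fold higher number from compound 1 to compound 2 (0.05 log units; within the scatter), is therefore no change beyond the scatter. Compound 3, `NC(=O)c1c(NC(=O)c2ccccc2Cl)sc2c1CCN(C(=S)Nc1ccccc1I)C2`, differs from compound 2 only by iodo in place of bromo on an aromatic carbon. Among the compounds with values here, no measured step touches this halogen exchange; the step from compound 1 to compound 2 exchanged the whole group on the ring amine nitrogen and still left the number within the scatter, which is the only guide available. On that basis the step from compound 2 to compound 3 is expected to be small, a 1.1-fold lower number from compound 2 to compound 3 (0.03 log units; within the scatter), with no direction beyond the scatter. Compound 3 is thus estimated at 8500 nM, in the range 4000 nM to 18000 nM.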

Compound 3, half-maximal inhibitory concentration: 4430 nM
The estimate for compound 3 lay 1.9-fold (0.28 log units) above the measured number; measured number inside the range.
By their numbers in this assay, from the lowest: compounds 3, 1 and 2 (each within the scatter of the next, the first and the last beyond it).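

In this assay, the aromatic carbon ortho to a large group responds to the exchange of one halogen: iodo in place of bromo gives a 2.1-fold lower number from compound 2 to compound 3 (0.31 log units; beyond the scatter), a modest step and the only one among these compounds beyond the scatter. The exchange of the whole group on the ring amine nitrogen with iodo present gives a 1.8-fold lower number from compound 1 to compound 3 (0.26 log units; within the scatter), so compound 3 cannot be separated from compound 1 on this read-out. Nothing available here accounts for the halogen step.

Going by these compounds, whether fluoro, methyl, methoxy or nitrile at this same carbon would give a step of similar size remains open. So does whether the iodo result would carry over to the other carbons of the aromatic ring or to a urea in place of the thiourea.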